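From Bromo to Fluoro: Estimating Compound 4

A few compounds are considered here, and "the series" means these few. Any claim that something is new, unique, unknown or untested is made for them only; others in the source may bear on it.

Compound 1 `O=C(CCl)Nc1ccc(C(=O)/C=C/c2ccc(F)cc2)cc1`: 15100 nM
Compound 2 `O=C(CSC(=S)N[C@H]1CCOC1=O)Nc1ccc(C(=O)/C=C/c2ccc(Cl)cc2)cc1`: > 128000 nM
Compound 3 `O=C(CSC(=S)N[C@H]1CCOC1=O)Nc1ccc(C(=O)/C=C/c2ccc(Br)cc2)cc1`: 18000 nM

All three results come from a functional assay on SMMC-7721 cells (Homo sapiens) for cytotoxicity, read by MTT assay, with a stated time of 72 h; on this read-out higher numbers stand for weaker inhibition and lower numbers for stronger inhibition. The value of compound 2 is a limit of the assay rather than a number (the limit of > 128000 nM in this assay, at which 1 of the 3 values shown sits). Among the numbers shown, compound 3 has the highest one, and its nearest neighbour is compound 1, whose number is lower by an amount that stays within the usual scatter.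

Compound 4 `O=C(CSC(=S)N[C@H]1CCOC1=O)Nc1ccc(C(=O)/C=C/c2ccc(F)cc2)cc1` has not yet been measured in this assay. It differs from compound 3 in one place: fluoro in place of bromo on an aromatic carbon. Among the compounds with values here, only one measured step bears on this change, a halogen swap on the same aromatic carbon, an at least 7.1-fold lower number from compound 2 to compound 3 (0.85 log units; beyond the scatter). That step gives no clear direction for fluoro: compound 2 sits at the limit and compound 3 gives a number. Compound 1 carries the same fluoro group on a different core and gives a number close to that of compound 3.

The estimate for compound 4 in this assay therefore leans toward a somewhat higher number, a 2.2-fold higher number from compound 3 to compound 4 (0.35 log units; beyond the scatter), with wide bounds. Compound 4 is expected to give 40000 nM, between 12000 nM and 128000 nM.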

Compound 4, half-maximal inhibitory concentration: > 128000 nM
Compound 4 ended at the assay's limit; the forecaster's own chance of this, stated with the estimate: 25%; at least 3.2-fold (0.50 log units) between middle value and limit.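

In this assay, the change from 4-bromophenyl to 4-fluorophenyl now has a readable size, an at least 7.1-fold higher number from compound 3 to compound 4 (0.85 log units; beyond the scatter), which leaves bromo as the only one of the three halogens at this place on the shared core to give a number, while chloro and fluoro both end at a limit of the assay: the limit of > 128000 nM in this assay, at which 2 of the 4 values shown sit. The step between compound 2 and compound 4 cannot be read, as both values are limits, so chloro and fluoro stay unordered. With fluoro held fixed, putting the group of 10 heavy atoms in place of the chlorine atom on the saturated chain carbon bound to a carbonyl carbon gives an at least 8.4-fold higher number from compound 1 to compound 4 (0.92 log units; beyond the scatter), so at this fluoro group the change on the chain also moves the result beyond the scatter.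

As far as these compounds go, whether an iodo, methyl or methoxy group at this place would give a number, as bromo does, or a limit remains open. Also open, from the compounds shown here alone, are how far past the limit compound 2 and compound 4 lie, and what a bromo group would do on the core of compound 1.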